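This account rests on a few compounds, and the source may have more. Where it says the series, first, only, none or still open, it means among the compounds named here.

In a functional assay on MCF7 cells (Homo sapiens) for antiproliferative activity, with a stated time of 96 h (a higher number here means a weaker inhibitor, a lower number a stronger inhibitor), compound 1 `Cc1cc(=O)oc2cc(OCC(=O)c3cc(C(F)(F)F)cc(C(F)(F)F)c3)ccc12` gives 470 nM, while compound 2 `Cc1cc(=O)oc2cc(OCC(=O)c3cccc(C(F)(F)F)c3)ccc12` gives 38400 nM, the higher of the two numbers available. Compound 3 `CC(C)(C)c1ccc(C(=O)COc2ccc3c(C(F)(F)F)cc(=O)oc3c2)cc1` is recorded as "not active" (no number reported). Compound 4 `O=C(COc1ccc2c(C(F)(F)F)cc(=O)oc2c1)c1cccc(C(F)(F)F)c1` departs from compound 2 on the shared core: trifluoromethyl in place of methyl on an aromatic carbon, opposite the ring oxygen. Going by the values given here, the only measured step, an 82-fold higher number from compound 1 to compound 2 (1.91 log units; beyond the scatter), is large, but it is a different change at a different place, so it says little about this one. Among the compounds with values here, no measured step covers the new change directly. The closest evidence is compound 3, which carries trifluoromethyl at the same place on the core and is recorded as "not active" (no number reported), although its other ring differs. With compound 2 already at 38400 nM, no clear gain is expected, and no step beyond the scatter is anticipated in this assay. The expected change is a 1.2-fold higher number from compound 2 to compound 4 (0.07 log units; within the scatter). For compound 4 the estimated value is 45000 nM, with an expected range from 12000 nM to 150000 nM.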

Compound 4, half-maximal inhibitory concentration: "not active" (no number reported)
Compound 4: no number reported; the estimate stays without a comparison.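

Going by these compounds alone, compound 4 is recorded without a number in this assay, so no step from compound 2 to compound 4 can be read. No other measurement shown bears on this result. The compounds shown leave open how far trifluoromethyl in place of methyl on the shared core shifts the number.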